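Swapping the benzyl substituent in a Huh-7 antiproliferative series

The compounds below may be only part of what the source reports. "The series", "measured", "known", "first", "only" and "open" are said of these compounds alone.

Compound 1 `FC(F)(F)c1ccc(CN2CCN(Cc3cc(-c4ccc(OCc5ccccc5Cl)cc4)on3)CC2)cc1` is the reference point of a small set tested in a functional assay on Huh-7 cells (Homo sapiens) for antiproliferative activity, read by sulforhodamine B assay, with a stated time of 72 h (on this read-out higher numbers stand for weaker inhibition and lower numbers for stronger inhibition), where compound 1 gives 1000 nM. Among the three measured compounds this is the lowest number, though the two neighbours do not separate from it beyond the scatter: compound 2 `Fc1ccccc1COc1ccc(-c2cc(CN3CCN(Cc4ccc(C(F)(F)F)cc4)CC3)no2)cc1` gives 1500 nM and compound 3 `Fc1ccc(COc2ccc(-c3cc(CN4CCN(Cc5ccc(C(F)(F)F)cc5)CC4)no3)cc2)cc1` gives 2000 nM, with a 1.5-fold higher number from compound 1 to compound 2 (0.18 log units; within the scatter) and a 2.0-fold higher number from compound 1 to compound 3 (0.30 log units; within the scatter).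

Compound 4 `COc1cccc(COc2ccc(-c3cc(CN4CCN(Cc5ccc(C(F)(F)F)cc5)CC4)no3)cc2)c1` differs from compound 1 by 3-methoxyphenyl in place of 2-chlorophenyl on a saturated chain carbon bound to an oxygen on an aromatic ring. For the measured compounds named here, the steps that bear on this change are those at the same place: a 2.0-fold higher number from compound 1 to compound 3 (0.30 log units; within the scatter) and a 1.3-fold higher number from compound 2 to compound 3 (0.12 log units; within the scatter). Both alter the ring on the saturated chain carbon bound to an oxygen on the aromatic ring, and neither moves the number beyond the scatter. A similar small shift towards a higher number is therefore expected for compound 4, and its estimated value in this assay is 1800 nM, within a range of 700 nM to 4500 nM, corresponding to an expected step of a 1.8-fold higher number from compound 1 to compound 4 (0.26 log units; within the scatter).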

Compound 4, half-maximal inhibitory concentration: 800 nM
Compound 4: the middle estimate sits 2.3-fold (0.35 log units) above what was measured; measured number inside the range.
By their numbers in this assay, from the lowest: compounds 4, 1, 2 and 3 (each within the scatter of the next, the first and the last beyond it).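

For the compounds shown here, the 3-methoxyphenyl ring gives the first step at this position that clears the scatter in this assay (a 2.5-fold lower number from compound 3 to compound 4 (0.40 log units; beyond the scatter)), whereas the earlier steps here all stayed within it. Compound 4 does not separate from the compounds carrying the 2-chlorophenyl or 2-fluorophenyl ring (a 1.3-fold lower number from compound 1 to compound 4 (0.10 log units; within the scatter); a 1.9-fold lower number from compound 2 to compound 4 (0.27 log units; within the scatter)), so the position takes this larger ring substituent, which adds a hydrogen-bond acceptor, with no measurable change against those two and a separation only from the 4-fluorophenyl ring of compound 3. No supporting data are available to account for that separation.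

From the compounds shown here alone, how a 2-methoxyphenyl or 4-methoxyphenyl ring would stand against compound 4 remains open. So does whether a hydroxyl or an ethoxy group on the same ring would read like the methoxy group.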